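Swapping a ring for a chain on the amide-like nitrogen

The source may report more compounds than this note shows. Statements on the series, on what has been measured and on what is new or still open speak of the compounds shown alone.

Measured compounds in an assay on HEK293 cells for positive allosteric modulation of metabotropic glutamate receptor 2 (Rattus norvegicus), read by thallium flux; a higher number here means a larger maximal response, a lower number a smaller maximal response:
compound 1 `O=C(O)c1cc(-c2cccc(COc3ccc4c(c3)CN(C3CCCC3)C4=O)c2)ccc1O` gives 90.1%
compound 2 `O=C(O)c1cc(-c2cccc(COc3ccc4c(=O)n(C5CCC5)sc4c3)c2)ccc1Cl` gives 83%
compound 3 `O=C(O)c1ccc(-c2cccc(COc3ccc4c(c3)CN(C3CCCC3)C4=O)c2)c(Cl)c1` gives 89.4%

Compound 2 sits within the usual scatter of both compound 3 and compound 1 in this assay, so the three cannot be told apart on these numbers. Within the data shown here, the only one-place step measured so far, a number 0.7 percentage points lower from compound 1 to compound 3 (within the scatter), concerns the acid-bearing aryl ring of the shared core and also stays within the scatter.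

Compound 4 `CC(C)Cn1sc2cc(OCc3cccc(-c4ccc(Cl)c(C(=O)O)c4)c3)ccc2c1=O` differs from compound 2 in one place: isobutyl in place of cyclobutyl on an aromatic nitrogen. Among the measured compounds shown here, no measured pair changes this group, so nothing in the data speaks for a shift in either direction. For the measured compounds named here, the one measured step being flat, and the change being a like-for-like swap of small carbon groups, the expectation is that compound 4 keeps the maximal response of compound 2, with the step of no change at the digits printed from compound 2 to compound 4 (within the scatter) expected to stay within the scatter. Compound 4 is therefore estimated at 83% in this assay, with a likely range from 68% to 98%.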

Compound 4, largest response reached (reported as percent of maximum), in percent of the reference or control that the assay uses: 76.2%
Beside the measured number, compound 4's estimate is 6.8 percentage points above it; the measured number falls inside the stated range.
By their numbers in this assay, from the lowest: compounds 4, 2, 3 and 1 (each within the scatter of the next, the first and the last beyond it).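

Among these compounds, this is the first measured change to the group on the aromatic nitrogen. Replacing cyclobutyl with isobutyl opens the four-membered ring while keeping the same count of carbon atoms, and in this assay this gives a number 6.8 percentage points lower from compound 2 to compound 4 (within the scatter), so the two compounds cannot be told apart. At this position, then, the ring itself is not needed to keep the maximal response within the scatter, at least for this one open-chain group of the same size. No measurement here offers an explanation for this reading.

The compounds shown leave open how a longer chain such as hexyl, or a chain ending in an amine, would behave on this nitrogen. They also do not show whether isobutyl in place of cyclopentyl would read the same on the core of compound 1.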